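Extending the Ether Chain on the Shared Core

The source may hold more compounds than are shown below. What is called first, only, known or untested is meant among the compounds shown, and "the series" means these compounds.

compound 1 `Nc1ccc(-c2cc(=O)c3c(N)c(F)c(N)c(F)c3o2)cc1F`: 19000 nM
compound 2 `COCc1c(F)c(N)c2c(=O)cc(-c3ccc(N)c(F)c3)oc2c1F`: > 100000 nM

In a functional assay on HeLa cells (Homo sapiens) for cytotoxicity, read by neutral red uptake, with a stated time of 3 days (on this read-out lower numbers stand for stronger inhibition and higher numbers for weaker inhibition), compound 1 gives 19000 nM. Compound 2 gives only > 100000 nM, which is a limit of the assay and not a number. Among the compounds with values here, the single measured step, an at least 5.2-fold higher number from compound 1 to compound 2 (0.72 log units; beyond the scatter), therefore rests on the limit of > 100000 nM in this assay, at which 1 of the 2 values shown sits, rather than on two numbers. Compound 3 `CCCOCc1c(F)c(N)c2c(=O)cc(-c3ccc(N)c(F)c3)oc2c1F` differs from compound 2 by ethyl in place of hydrogen on a saturated chain carbon bound to an oxygen on a saturated carbon. Within the data shown here, no measured step touches this part of the molecule, so there is nothing here that speaks for a move back toward the stronger inhibition seen with compound 1. Since the only anchor is the limit of > 100000 nM in this assay, at which 1 of the 2 values shown sits, the expected step is a step that the limit leaves unreadable from compound 2 to compound 3, meaning no change beyond the scatter. Compound 3 is thus estimated at 150000 nM, with a range from 40000 nM to 500000 nM, and most likely again reported only as a limit.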

Compound 3, half-maximal inhibitory concentration: 78000 nM
Compound 3: the middle estimate sits 1.9-fold (0.28 log units) above what was measured; the measured number falls inside the stated range.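

With the longer propoxymethyl chain, compound 3 gives 78000 nM, so a group of this ether type on this aromatic carbon can now be set against the amino group of compound 1 on two real numbers: a 4.1-fold higher number from compound 1 to compound 3 (0.61 log units; beyond the scatter). Adding ethyl to the methoxymethyl chain gives a smaller and less certain reading: an at least 1.2-fold lower number from compound 2 to compound 3 (0.10 log units; that floor lies within the scatter). That step only sets a minimum, and its true size stays unknown, because compound 2 carries a limit of the assay and not a number: the limit of > 100000 nM in this assay, at which 1 of the 3 values shown sits.

The compounds shown leave open whether a still longer ether chain, such as butoxymethyl, would lower the number further or raise it again. They also leave open how a dimethylamine or a carboxylic acid on the same aromatic carbon would compare with the amino group of compound 1.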